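Removing One Methoxy Group from Compound 2

A few compounds are considered here, and "the series" means these few. Any claim that something is new, unique, unknown or untested is made for them only; others in the source may bear on it.

Measured compounds:
Compound 1 `COc1ccc(-c2cc(/C=C/C(=O)c3ccc(N)cc3)[nH]n2)cc1` gives -93% in a functional assay on HCC 2998 cells (Homo sapiens) for cytotoxicity, read by sulforhodamine B assay, with a stated time of 48 h, tested at 100 uM; a higher number here means a weaker effect of the compound at the concentration tested, a lower number a stronger effect.
Compound 2 `COc1cc(-c2cc(/C=C/C(=O)c3ccc(N)cc3)[nH]n2)cc(OC)c1OC` gives -91% in this assay.
Compound 3 `COc1ccc(C(=O)/C=C/c2cc(-c3cc(OC)c(OC)c(OC)c3)n[nH]2)cc1` gives -82% in this assay.

Among these three numbers compound 2 stands second highest; the nearest is compound 1, the furthest compound 3, and the one measured step, a number 9 percentage points higher from compound 2 to compound 3 (within the scatter), lies within the scatter. Compound 4 `COc1ccc(-c2cc(/C=C/C(=O)c3ccc(N)cc3)[nH]n2)cc1OC` differs from compound 2 in one place: hydrogen in place of methoxy on an aromatic carbon. Within the data shown here, no measured step removes a methoxy group; the only measured step, from compound 2 to compound 3, changes a different group and stays within the scatter. Compounds 1 and 2 carry different numbers of methoxy groups yet show values within the scatter of each other, and compound 4 carries more methoxy groups than compound 1 and fewer than compound 2. So no step beyond the scatter is expected in this assay. Compound 4 is expected to give -91%, between -100% and -78%. The step of no change at the digits printed from compound 2 to compound 4 (within the scatter) is expected to stay within the scatter.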

Compound 4, a percentage reported as activity, at one concentration (the size of the read-out at that concentration, not a potency): -91%
For compound 4 middle estimate and measured number coincide at the digits printed; the measured number falls inside the stated range.
By their numbers in this assay, from the lowest: compounds 1, 2, 4 and 3 (each within the scatter of the next, the first and the last beyond it).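

Hydrogen in place of methoxy, on an aromatic carbon ortho to a methoxy group, gives no change at the digits printed from compound 2 to compound 4 (within the scatter) in this assay, the first measured step at this place on the ring. The matching step that puts a methoxy group onto compound 1 gives a number 2 percentage points higher from compound 1 to compound 4 (within the scatter) and so also stays small, which means that neither single change at the methoxy-bearing ring moves the read-out beyond the usual scatter of this measurement. Nothing available explains this lack of a step.

The compounds shown leave open whether a different group at this place, such as a hydroxy group, a fluorine atom or a longer chain like ethoxy, would also stay within the scatter. With a read-out taken at a single concentration, they also leave open whether any of these compounds would show a stronger or weaker effect at another concentration.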